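A few compounds are considered here, and "the series" means these few. Any claim that something is new, unique, unknown or untested is made for them only; others in the source may bear on it.

Measured compounds:
compound 1, `O=C(O)C1CCN(c2ccc(C(F)(F)F)cc2)C1`, with 50000 nM in an assay on cells for inhibition of Palmitoleoyl-protein carboxylesterase NOTUM variant C330S (Homo sapiens), read by fluorescence, with a stated time of 40 min; a lower number here means a stronger inhibitor, a higher number a weaker inhibitor;
compound 2, `O=C(O)C1CCN(c2cccc(Cl)c2Cl)C1`, with 8000 nM in this assay.

Among the measured compounds shown here, compound 2 gives the lowest of the two numbers measured so far in this assay. Its nearest neighbour is compound 1, whose number lies beyond the usual scatter of this assay, so compound 2 is the stronger inhibitor of the pair. For the measured compounds named here, no step between measured compounds that differ in one place is available, so the only guide to what a single change does is this gap between two compounds that differ in more than one respect.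

Compound 3, `O=C(O)C1CCN(c2ccc(Cl)c(Cl)c2Cl)C1`, is not yet measured. It differs from compound 2 by one change: chloro in place of hydrogen on an aromatic carbon. With no single-point step among the measured compounds to rest on, the expected size of this step is uncertain; on the numbers shown, compound 2 with its 8000 nM sets the starting point, and a further chloro group on the same ring is expected to give a modest gain, a step of a 2.7-fold lower number from compound 2 to compound 3 (0.43 log units; beyond the scatter), going beyond the scatter but not by a large margin. For compound 3 the estimated value in this assay is 3000 nM, expected to lie between 800 nM and 12000 nM.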

Compound 3, half-maximal inhibitory concentration: 600 nM
For compound 3 the middle estimate is 5.0-fold (0.70 log units) above the measured one; the whole stated range lies above it.
By their numbers in this assay, from the lowest: compound 3; then compound 2; then compound 1.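

In this assay the series now has its first step between compounds that differ in one place: chloro in place of hydrogen on an aromatic carbon gives a 13-fold lower number from compound 2 to compound 3 (1.12 log units; beyond the scatter) and counts as a large step, well beyond the scatter. The earlier pair could not show this, since compound 1 and compound 2 differ in more than one respect, whereas here the whole change comes from a single chlorine atom. It shows that this ring carbon, ortho to a chloro group, meta to a chloro group and para to a group of 8 heavy atoms, is a place where one added heavy atom strongly lowers the number, even on a ring that already carries two chloro groups.

Still open, on these data alone, is whether another group at this same carbon, such as methyl, methoxy, nitrile or an amine, would do as well as chloro, and whether the gain would survive if the neighbouring chloro groups were taken away or the carboxylic acid were replaced by an amide. Nothing measured here offers a reason for the size of this step.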